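A Second Chlorine on the Phenyl Ether Tail

A few compounds are considered here, and "the series" means these few. Any claim that something is new, unique, unknown or untested is made for them only; others in the source may bear on it.

Three compounds sharing one core have been examined in an assay on isolated protein for inhibition of Dihydrofolate reductase (Homo sapiens), read by spectrophotometry, using NADPH, with stated times of 5 s and 6 min, tested at 5 uM; a higher number here means a stronger effect of the compound at the concentration tested, a lower number a weaker effect. Compound 1 `NC1=NC2(CCOCC2)N(OCCCOc2ccccc2)C(N)=N1` carries a plain phenyl group at the end of its ether chain, and in this assay compound 1 gives > 90%, which is a limit of the assay rather than a number. Compound 2 `COc1ccc(OCCCON2C(N)=NC(N)=NC23CCOCC3)cc1` bears a methoxy group on that ring, and in this assay compound 2 gives > 90%, again a limit. Compound 3 `NC1=NC2(CCOCC2)N(OCCCOc2ccc(Cl)cc2)C(N)=N1` bears a chloro group instead, and in this assay compound 3 gives > 90%, also a limit. Compound 3 therefore stands at the limit of > 90% in this assay, at which 3 of the 3 values shown sit. The steps between these compounds, a step that the two limits leave unreadable from compound 1 to compound 2, a step that the two limits leave unreadable from compound 1 to compound 3 and a step that the two limits leave unreadable from compound 2 to compound 3, are of a size the limit leaves unreadable. Compound 4 `NC1=NC2(CCOCC2)N(OCCCOc2cccc(Cl)c2Cl)C(N)=N1` differs from compound 3 by 2,3-dichlorophenyl in place of 4-chlorophenyl on an oxygen on a saturated carbon. With every measured step unreadable in size, compound 4 is expected to move by a step that the limit leaves unreadable from compound 3 to compound 4, not beyond the scatter. Compound 4 is expected to give 93%, between 85% and 100%, most likely reported again as a limit.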

Compound 4, a percentage reported as inhibition, at one concentration (the size of the read-out at that concentration, not a potency): 81.7%
The estimate for compound 4 lay 11.3 percentage points above the measured number; measured number outside the range, below it.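

Within the data shown here, compound 4 is the first compound in this set to give a number rather than a limit, so the ether tail can now be compared, if only partly. In this assay, exchanging the 4-chlorophenyl gives a number at least 8.3 percentage points lower from compound 3 to compound 4 (that floor lies within the scatter), while the comparisons with the other two tails give a number at least 8.3 percentage points lower from compound 2 to compound 4 (that floor lies within the scatter) and a number at least 8.3 percentage points lower from compound 1 to compound 4 (that floor lies within the scatter). These steps can be stated only as floors, and the steps among the first three compounds cannot be read at all, because those compounds share one limit: the limit of > 90% in this assay, at which 3 of the 4 values shown sit.

Going by these compounds, whether the true gap exceeds the scatter stays open, as does whether any difference would come from the second chlorine or from where the chlorines sit. Also open, on these data alone, is how this assay would read with an amine or a carboxylic acid on the ring, or with a longer chain.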